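Moving the Methyl: From Compound 3 to Compound 4

The source may report more compounds than this note shows. Statements on the series, on what has been measured and on what is new or still open speak of the compounds shown alone.

Of the compounds shown here, three on a shared core have been measured. Compound 1 `CS(=O)(=O)c1ccc(-c2cnc3[nH]cc(-c4nnc(-c5ccccc5)o4)c(=O)c3c2)cc1` carries an unsubstituted phenyl on the five-membered ring; compound 2 `CS(=O)(=O)c1ccc(-c2cnc3[nH]cc(-c4nnc(-c5ccc(Cl)cc5)o4)c(=O)c3c2)cc1` bears a chloro and compound 3 `Cc1ccc(-c2nnc(-c3c[nH]c4ncc(-c5ccc(S(C)(=O)=O)cc5)cc4c3=O)o2)cc1` a methyl in place of a hydrogen on an aromatic carbon of that phenyl. In a functional assay on A549 cells (Homo sapiens) for inhibition, read by MTT assay, with a stated time of 24 h, tested at 5 uM (a higher number here means more inhibition of growth at the concentration tested, a lower number less inhibition of growth), compound 1 gives 8.17%, compound 2 gives 23.8%, and compound 3 gives 6.69%. Compound 3 thus has the lowest of the three numbers, but its gap to compound 1 is within the scatter, so the two cannot be ordered; only compound 2 stands clearly apart. The steps show this: a number 15.6 percentage points higher from compound 1 to compound 2 (beyond the scatter), a number 1.5 percentage points lower from compound 1 to compound 3 (within the scatter), and a number 17.1 percentage points lower from compound 2 to compound 3 (beyond the scatter).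

Compound 4 `Cc1cccc(-c2nnc(-c3c[nH]c4ncc(-c5ccc(S(C)(=O)=O)cc5)cc4c3=O)o2)c1` is the next candidate, differing from compound 3 by 3-methylphenyl in place of 4-methylphenyl on an aromatic carbon. Among the compounds with values here, none of the measured steps moves a group from one place to another on that phenyl; they only exchange the group at one place. The step nearest in kind, from compound 1 to compound 3, was within the scatter, and the data give no sign that the position of the methyl matters. The expected step is therefore a number 1.3 percentage points higher from compound 3 to compound 4 (within the scatter), a change that stays within the scatter. For compound 4 the estimated value in this assay is 8%, with a range from 0% to 22%.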

Compound 4, percent growth inhibition at one concentration: 7.92%
Estimate against measurement, compound 4: 0.1 percentage points above; measured number inside the range.
By their numbers in this assay, from the lowest: compounds 3, 4 and 1 (each within the scatter of the next); then compound 2.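

In this assay, moving the methyl from 4-methylphenyl to 3-methylphenyl gives a step within the scatter (a number 1.2 percentage points higher from compound 3 to compound 4 (within the scatter)), so on this phenyl, which sits on an aromatic carbon of the five-membered aromatic ring, the place of the methyl has no readable effect at the single concentration tested. The 3-methylphenyl of compound 4 also cannot be told apart from the unsubstituted phenyl (a number 0.3 percentage points lower from compound 1 to compound 4 (within the scatter)), while the step from the 4-chlorophenyl remains beyond the scatter (a number 15.9 percentage points lower from compound 2 to compound 4 (beyond the scatter)), although that step exchanges the group and shifts its place together. Nothing available bears on the reason for these numbers.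

On these data alone, what remains open is whether the higher number of compound 2 belongs to the chloro itself or to its place on the phenyl, which a 3-chlorophenyl on the shared core would help to separate. The compounds shown also leave unknown how this phenyl would respond to an amine, a carboxylic acid or a longer chain such as butyl in place of the methyl.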